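The source may hold more compounds than are shown below. What is called first, only, known or untested is meant among the compounds shown, and "the series" means these compounds.

Cytotoxicity in this series is read in an ADME assay on HEK-293T cells (Homo sapiens) for cytotoxicity, read by CCK-8 assay, with a stated time of 24 h; a lower number here means that less compound is tolerated, a higher number that more compound is tolerated. Values so far:

compound 1 `CN(Cc1ccccc1)C(=O)CSc1c[nH]c2c(Br)cccc12`: 52500 nM
compound 2 `O=C(CSc1c[nH]c2c(Br)cccc12)N(Cc1ccccc1)Cc1ccccc1`: > 100000 nM, which is a limit of the assay and not a number
compound 3 `CN(Cc1ccccc1)C(=O)CSc1c[nH]c2cccc(Br)c12`: 25100 nM

Compound 3 has the lowest of the two numbers; the difference between its core and the core of compound 1 is not broken down here. From compound 1 to compound 2 the change is phenyl in place of hydrogen on a saturated chain carbon bound to an amide-type nitrogen, and the step it gave is an at least 1.9-fold higher number from compound 1 to compound 2 (0.27 log units; that floor lies within the scatter), with compound 2 sitting at the limit of > 100000 nM in this assay, at which 1 of the 3 values shown sits.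

Compound 4 `O=C(CSc1c[nH]c2cccc(Br)c12)N(Cc1ccccc1)Cc1ccccc1` is not yet measured. It differs from compound 3 by phenyl in place of hydrogen on a saturated chain carbon bound to an amide-type nitrogen, the same change. The step from compound 3 to compound 4 in this assay is expected at a 2.4-fold higher number from compound 3 to compound 4 (0.38 log units; beyond the scatter), which rests on an at least 1.9-fold higher number from compound 1 to compound 2 (0.27 log units; that floor lies within the scatter) and on compound 3 standing at 25100 nM. Compound 4 is estimated at 60000 nM, expected between 25000 nM and 150000 nM.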

Compound 4, half-maximal cytotoxic concentration: 25700 nM
The estimate for compound 4 lay 2.3-fold (0.37 log units) above the measured number; the measured number falls inside the stated range.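

In this assay, the methyl to benzyl change on the core of compound 3 gives a 1.0-fold higher number from compound 3 to compound 4 (0.01 log units; within the scatter), so the two compounds cannot be told apart on this core. Compound 2 is reported as > 100000 nM, which is a limit of the assay and not a number. The two cores therefore show neither that the change carries over nor that its result depends on the core: the same change on two cores in this assay, an at least 1.9-fold higher number (0.27 log units; that floor lies within the scatter) from compound 1 to compound 2 and a 1.0-fold higher number (0.01 log units; within the scatter) from compound 3 to compound 4; the limit leaves it open whether they differ

With only these two pairs, the compounds shown leave open how the same change would read on any other core. They also leave open how this assay would read with a carboxylic acid or a longer chain carrying an amine in place of benzyl.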